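Pyridine for Pyrazole on a Chlorobenzamide Core

The compounds below may be only part of what the source reports. "The series", "measured", "known", "first", "only" and "open" are said of these compounds alone.

Compound 1 `Cc1cc(-c2ccc(Cl)c(C(=O)NCC3(O)CCCC(C)(C)C3)c2)n[nH]1` gives 7.94 nM in a functional assay on THP-1 cells for antagonist activity at P2X purinoceptor 7 (Homo sapiens) (a lower number here means a stronger inhibitor, a higher number a weaker inhibitor), the higher of the two numbers recorded. Compound 2 `Cc1cc(-c2ccc(Cl)c(C(=O)NCC3(O)CCCCCC3)c2)nn1CC(=O)NCCN(C)C` gives 3.16 nM in this assay, a lower number that lies beyond the usual scatter. Compound 3 `Cc1ccc(-c2ccc(Cl)c(C(=O)NCC3(O)CCCC(C)(C)C3)c2)nc1` carries 5-methylpyridin-2-yl in place of 5-methyl-1H-pyrazol-3-yl on an aromatic carbon. Going by the values given here, no measured pair shows this exchange, so the expected 1.9-fold higher number from compound 1 to compound 3 (0.28 log units; within the scatter) is modest, if anything toward a weaker inhibitor, and possibly within the scatter. Compound 3 is therefore estimated at 15 nM, with a range from 4 nM to 60 nM.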

Compound 3, half-maximal inhibitory concentration: 10 nM
Beside the measured number, compound 3's estimate is 1.5-fold (0.18 log units) above it, and the stated range covers the measured number.
By their numbers in this assay, from the lowest: compound 2; then compounds 1 and 3 (each within the scatter of the next).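

With the dimethylcyclohexyl amide side held constant, the exchange of 5-methyl-1H-pyrazol-3-yl for 5-methylpyridin-2-yl gives a 1.3-fold higher number from compound 1 to compound 3 (0.10 log units; within the scatter) in this assay. At this aromatic carbon, a six-membered aromatic ring with no hydrogen-bond donor therefore reads the same as the five-membered ring with one, within the scatter of this assay. No measurement shown accounts for this result. The compounds shown leave open whether a plain phenyl ring or a pyrimidine would read the same at this place. They also leave open what an amine or a longer chain on the pyridine would do.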